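This account rests on a few compounds, and the source may have more. Where it says the series, first, only, none or still open, it means among the compounds named here.

Within the data shown here, in an ADME assay on HEK293 cells (Homo sapiens) for cytotoxicity, read by MTT assay, with a stated time of 48 h (a lower number here means a stronger inhibitor, a higher number a weaker inhibitor), compound 1 (`Cc1ccc(/C=C2/S/C(=N/c3ccccc3)N(Cc3ccncc3)C2=O)cc1`) gives 49500 nM and compound 2 (`CC(C)c1ccc(/C=C2/S/C(=N/c3ccccc3)N(Cc3ccncc3)C2=O)cc1`) gives 137000 nM, so compound 2 holds the higher of the two numbers measured so far. Compound 3 (`O=C1/C(=C\c2ccc(O)c(O)c2)S/C(=N/c2ccccc2)N1Cc1ccncc1`) has not yet been measured. It differs from compound 2 by 3,4-dihydroxyphenyl in place of 4-isopropylphenyl on a double-bonded chain carbon bound to a double-bonded ring carbon. Among the measured compounds shown here, only one measured step bears on this change, and only in part: a 2.8-fold higher number from compound 1 to compound 2 (0.44 log units; beyond the scatter), a modest step beyond the scatter, with isopropyl in place of methyl on an aromatic carbon. For the measured compounds named here, compound 3 gives up that isopropyl group, but no measured compound carries 3,4-dihydroxyphenyl, so the guidance is thin. A modest step of similar size towards a lower number is therefore expected in this assay. The expected change is a 3.0-fold lower number from compound 2 to compound 3 (0.48 log units; beyond the scatter). Compound 3 is estimated at 45000 nM, with an expected range from 12000 nM to 140000 nM.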

Compound 3, half-maximal inhibitory concentration: 230000 nM
Compound 3: middle estimate off by 5.1-fold (0.71 log units), on the low side; measured number outside the range, above it.
By their numbers in this assay, from the lowest: compound 1; then compounds 2 and 3 (each within the scatter of the next).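

In this assay, 3,4-dihydroxyphenyl in place of 4-isopropylphenyl on a double-bonded chain carbon bound to a double-bonded ring carbon comes to a 1.7-fold higher number from compound 2 to compound 3 (0.23 log units; within the scatter), so this exchange does not separate compound 2 from compound 3, although the entering group has 2 hydrogen-bond donors and 2 hydrogen-bond acceptors and the leaving group has 0 of each. Against 4-methylphenyl at the same place, 3,4-dihydroxyphenyl gives a 4.6-fold higher number from compound 1 to compound 3 (0.67 log units; beyond the scatter), so among these three compounds only compound 1 stands apart, and isopropyl is not needed for a reading in the range of compound 2. No evidence at hand accounts for this result.

From the compounds shown here alone, what a phenyl carrying a single hydroxyl, or methoxy groups in place of both hydroxyls, would give at this place remains open, and so does whether the hydroxyls act together or separately. The three compounds also share the rest of the core, so they leave open whether the same reading would hold with an amine or a carboxylic acid on the phenyl ring or with another group elsewhere on the core.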